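A few compounds are considered here, and "the series" means these few. Any claim that something is new, unique, unknown or untested is made for them only; others in the source may bear on it.

Measured so far:
- compound 1, `CC1=C(/C=C/C(=O)/C=C/c2cc(C(F)(F)F)ccc2C(F)(F)F)C(C)(C)CCC1O`: "not determined" (no result reported) in a functional assay on CWR22R cells (Homo sapiens) for cytotoxicity, read by MTT assay, with a stated time of 72 h; a lower number here means a stronger inhibitor, a higher number a weaker inhibitor
- compound 2, `CC1=C(/C=C/C(=O)/C=C/c2ccccc2F)C(C)(C)CCC1O`: 3300 nM

Among the measured compounds shown here, only two compounds have been taken into this assay, and only one of them has produced a number. Compound 1, which carries two trifluoromethyl groups on its aromatic ring, has no result reported in this assay. For the measured compounds named here, compound 2, which carries a single fluoro group on that ring, is therefore the only compound with a value here: in this assay compound 2 gives 3300 nM, and with no second number beside it there is nothing to rank it against.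

The next compound keeps the whole of compound 2 and changes one spot on the aromatic ring. Compound 3, `CC1=C(/C=C/C(=O)/C=C/c2cc(C(F)(F)F)ccc2F)C(C)(C)CCC1O`, differs from compound 2 by trifluoromethyl in place of hydrogen on an aromatic carbon. Going by the values given here, no step between measured compounds is available to say what this kind of change does in this assay, so the expectation rests on compound 2 alone and on the modest size of the change. The step from compound 2 to compound 3 is estimated to be small, a 1.3-fold lower number from compound 2 to compound 3 (0.12 log units; within the scatter), most likely within the usual scatter. Compound 3 is expected to give about 2500 nM in this assay, with a range from 800 nM to 8000 nM.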

Compound 3, half-maximal inhibitory concentration: 2000 nM
Compound 3: the middle estimate sits 1.3-fold (0.10 log units) above what was measured; the range from low to high includes it.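

In this assay, among the compounds shown here, the first readable step on this aromatic ring is a 1.7-fold lower number from compound 2 to compound 3 (0.22 log units; within the scatter) and, as that step lies within the scatter, compound 3 cannot be told apart from compound 2 in this assay. For this one pair, then, trifluoromethyl with its 4 heavy atoms can take the place of hydrogen on this aromatic carbon, meta to a large group and para to a fluoro group, with no change larger than repeated measurements of the same compound would be expected to show. No measurement is available that explains this outcome.

Still open, as far as these compounds go, is whether a different group on the same carbon, such as an amine, a carboxylic acid or a longer chain, would move the number beyond the scatter, since a single pair says nothing about groups of other kinds. From the compounds shown here alone, compound 1 has trifluoromethyl where compound 3 has its fluoro group, but with no number for compound 1, that comparison cannot be read, and the effect of changing the fluoro group remains unknown.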